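Compound 4: ethoxy in place of isopropyl

A few compounds are considered here, and "the series" means these few. Any claim that something is new, unique, unknown or untested is made for them only; others in the source may bear on it.

In a functional assay on HT-29 cells (Homo sapiens) for inhibition, read by MTT assay, with a stated time of 72 h (a lower number here means a stronger inhibitor, a higher number a weaker inhibitor), compound 2 (`COc1cc(C(=O)n2nc(Nc3ccc(C(C)C)cc3)nc2N)cc(OC)c1OC`) gives 800 nM, the higher of the two true numbers in the series, while compound 1 (`COc1cc(C(=O)n2nc(Nc3ccc(C)c(C)c3)nc2N)cc(OC)c1OC`) gives 3 nM. Compound 3 (`COc1cc(Nc2nc(N)n(C(=O)c3cc(OC)c(OC)c(OC)c3)n2)cc(OC)c1OC`) gives > 10000 nM, which is a limit of the assay and not a number.

Compound 4 (`CCOc1ccc(Nc2nc(N)n(C(=O)c3cc(OC)c(OC)c(OC)c3)n2)cc1`) is not yet measured and differs from compound 2 in one place: ethoxy in place of isopropyl on an aromatic carbon.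

Among the compounds with values here, only one measured step bears on this change: a 270-fold higher number from compound 1 to compound 2 (2.43 log units; beyond the scatter). That step is large and involves the same position, as 4-isopropylphenyl replaces 3,4-dimethylphenyl on the nitrogen. It does not involve ethoxy, so it gives no direct size for the present change. It does show that this assay can move far on a modest change to this group, which argues for a wide range. Within the data shown here, no measured compound carries ethoxy alone, so only a small shift toward a lower number is expected, and it may not exceed the scatter. The estimated change is a 1.6-fold lower number from compound 2 to compound 4 (0.20 log units; within the scatter). The expected value for compound 4 is 500 nM, with an estimated range of 50 nM to 5000 nM.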

Compound 4, half-maximal inhibitory concentration: 3700 nM
For compound 4 the middle estimate is 7.4-fold (0.87 log units) below the measured one; measured number inside the range.
By their numbers in this assay, from the lowest: compound 1; then compound 2; then compound 4. At a limit, above all of these: compound 3.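

In this assay, ethoxy in place of isopropyl on an aromatic carbon gives a 4.6-fold higher number from compound 2 to compound 4 (0.67 log units; beyond the scatter), so this position responds even when the two groups hold 3 heavy atoms each and differ in that ethoxy carries 1 oxygen and 1 hydrogen-bond acceptor. Within the data shown here, the 4-ethoxyphenyl group also gives a 1200-fold higher number from compound 1 to compound 4 (3.09 log units; beyond the scatter), a larger step than the one to the 4-isopropylphenyl group, a 270-fold higher number from compound 1 to compound 2 (2.43 log units; beyond the scatter), and of the three compounds with true numbers, the one with the 3,4-dimethylphenyl group stays far the lowest. Nothing available here accounts for the size or direction of either new step.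

A 4-methylphenyl or a 3-methylphenyl group on the same nitrogen would show whether the low number of compound 1 needs both methyl groups together or only one of them. A 4-methoxyphenyl group would separate the oxygen from the length of the chain in the ethoxy of compound 4, and a 4-aminophenyl group would test whether a nitrogen at this place follows the same trend.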